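An Ester Arm in Place of Isopropyl on the Amine

The compounds below may be only part of what the source reports. "The series", "measured", "known", "first", "only" and "open" are said of these compounds alone.

Going by the values given here, compound 3 `CC(C)N(Cc1ccc(C#N)cc1)[C@@H]1CN[C@H](C(=O)N2CCSC2)C1` holds the only number among the three measured compounds: in an assay on a cell-free system (plasma) for inhibition of Dipeptidyl peptidase 4 (Rattus norvegicus), read by fluorescence (a higher number here means a weaker inhibitor, a lower number a stronger inhibitor), compound 3 gives 12.5 nM. Compound 1 `O=C([C@@H]1C[C@H](NS(=O)(=O)c2ccccc2)CN1)N1CCSC1` sits at a limit of this assay, giving > 300 nM. Compound 2 `N#Cc1ccc(S(=O)(=O)N[C@@H]2CN[C@H](C(=O)N3CCSC3)C2)cc1` likewise sits at a limit, giving > 300 nM in this assay. The step that the two limits leave unreadable from compound 1 to compound 2 cannot be read, as the limit of > 300 nM in this assay, at which 2 of the 3 values shown sit, makes plain. Compound 4 `CCOC(=O)CN(Cc1ccc(C#N)cc1)[C@@H]1CN[C@H](C(=O)N2CCSC2)C1` differs from compound 3 by (ethoxycarbonyl)methyl in place of isopropyl on an amine nitrogen. Among the compounds with values here, no measured step touches this amine substituent, so the expectation rests on compound 3 alone. The change is expected to move this assay only modestly, a 2.0-fold higher number from compound 3 to compound 4 (0.30 log units; within the scatter). Compound 4 is estimated at 25 nM in this assay, with a range from 6 nM to 100 nM.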

Compound 4, half-maximal inhibitory concentration: 15.3 nM
For compound 4 the middle estimate is 1.6-fold (0.21 log units) above the measured one, and the stated range covers the measured number.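

Going by these compounds alone, the step of a 1.2-fold higher number from compound 3 to compound 4 (0.09 log units; within the scatter) in this assay is the first readable one at this amine nitrogen, and it places the two compounds level. There, (ethoxycarbonyl)methyl, with 6 heavy atoms and 2 hydrogen-bond acceptors, stands in for isopropyl, with 3 heavy atoms and 0 hydrogen-bond acceptors, without moving the read-out beyond the scatter. Nothing shown here speaks to why the two groups read alike. Going by these compounds, whether a carboxylic acid in place of the ethyl ester would read the same stays open. So does the reading of a longer chain or a ring on this nitrogen.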